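A few compounds are considered here, and "the series" means these few. Any claim that something is new, unique, unknown or untested is made for them only; others in the source may bear on it.

Compound 1 `CC1=C([Se]CC(OC(=O)[C@@H](CO)NC(=O)OC(C)(C)C)C(=O)NC(C)(C)C)C(=O)c2ccccc2C1=O` and compound 2 `CC1=C([Se]CC(OC(=O)[C@@H](CO)NC(=O)OC(C)(C)C)C(=O)NCCCCCC(=O)OCc2ccccc2)C(=O)c2ccccc2C1=O` were both tested in a functional assay on MCF7 cells (Homo sapiens) for cytotoxicity, read by MTT assay, with a stated time of 24 h; on this read-out lower numbers stand for stronger inhibition and higher numbers for weaker inhibition. In this assay compound 1 gives 3000 nM, and compound 2 gives 5000 nM. Of the two numbers, compound 1 has the lower one, but the gap to compound 2 lies within the usual scatter of repeated measurements, so the two compounds cannot be told apart on these data.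

Compound 3 `CC1=C([Se]CC(OC(=O)[C@@H](CSSC(C)(C)C)NC(=O)OC(C)(C)C)C(=O)NC(C)(C)C)C(=O)c2ccccc2C1=O` has not yet been measured. It differs from compound 1 in one place: ((tert-butyl)sulfanyl)sulfanyl in place of hydroxy on a saturated chain carbon, two bonds along the chain from an amide-type nitrogen and a carbonyl carbon. In the shorter wording, this is a hydroxymethyl becoming a (((tert-butyl)sulfanyl)sulfanyl)methyl. Within the data shown here, no measured pair in this set shows a comparable change, so there is nothing here to say how large a step it should bring or in which direction. The expectation is therefore that the step from compound 1 to compound 3, a 1.2-fold lower number from compound 1 to compound 3 (0.08 log units; within the scatter), stays close to the scatter, with a wide range to allow for a real shift either way. On that basis compound 3 is estimated at 2500 nM in this assay, with a likely range from 800 nM to 8000 nM.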

Compound 3, half-maximal inhibitory concentration: 3000 nM
The estimate for compound 3 lay 1.2-fold (0.08 log units) below the measured number, within the range that was stated.
By their numbers in this assay, from the lowest: compounds 1, 3 and 2 (each within the scatter of the next).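

Among these compounds, this is the first pair here that differs in one place, and it shows that in this assay a hydroxymethyl can become an (((tert-butyl)sulfanyl)sulfanyl)methyl with no change at the digits printed from compound 1 to compound 3 (within the scatter). On paper the change is large: hydroxy, with 1 heavy atom and 1 hydrogen-bond donor, leaves, and ((tert-butyl)sulfanyl)sulfanyl, with 6 heavy atoms and 0 hydrogen-bond donors, enters, yet the number stays within the scatter, so at least in this pair the position accepts the much bigger group without a measurable penalty or gain. No measurement given here accounts for this outcome, so it stands as an observation without an explanation.

On these data alone, it remains open whether other groups on this saturated chain carbon, such as an amine, a carboxylic acid or a methyl ether in place of the hydroxy, would also leave the number unmoved. As far as these compounds go, it is equally open whether the same change, applied to compound 2, would give a similarly small step, since a single pair cannot show whether the result holds for a different amide partner.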